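Compound 3 to compound 4: the double bond leaves

A few compounds are considered here, and "the series" means these few. Any claim that something is new, unique, unknown or untested is made for them only; others in the source may bear on it.

Values in a functional assay on NCI-H23 cells (Homo sapiens) for antiproliferative activity, read by sulforhodamine B assay (a higher number here means a weaker inhibitor of growth, a lower number a stronger inhibitor of growth), are these.
Compound 1 `CC(C)CCCOc1cccc(O)c1C(=O)/C=C/c1ccc(O)cc1` gives 11400 nM as a number.
Compound 2 `COc1cccc(OCCC(C)(C)C)c1C(=O)/C=C/c1ccc(O)cc1` gives > 30000 nM as a limit.
Compound 3 `CC(C)=CCOc1cccc(O)c1C(=O)/C=C/c1ccc(O)cc1` gives > 30000 nM as a limit.

Compound 3 has no number on this scale, since its > 30000 nM is a limit. It shares that position with compound 2, and only compound 1 has a measured number. Compound 4 `CCCCOc1cccc(O)c1C(=O)/C=C/c1ccc(O)cc1` has not yet been measured. It departs from compound 3 as follows: propyl in place of 2-methylprop-1-en-1-yl on a saturated chain carbon bound to an oxygen on an aromatic ring. The double bond outside aromatic rings therefore goes, and the group that enters is saturated, as isopentyl is in compound 1.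

Going by the values given here, one measured step bears on this: an at least 2.6-fold higher number from compound 1 to compound 3 (0.42 log units; beyond the scatter), which brought in the 2-methylprop-1-en-1-yl group that compound 4 now gives up. Among the compounds with values here, a modest step toward a lower number is therefore expected in this assay, although propyl itself has no measured step, and a limit could again be reported. The expected change is an at least 1.5-fold lower number from compound 3 to compound 4 (0.17 log units; that floor lies within the scatter), an estimate only. Compound 4 is estimated at 20000 nM, with an expected range from 9000 nM to 40000 nM as the outer end.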

Compound 4, concentration for 50% growth inhibition: > 30000 nM
Compound 4 was reported as a limit; the forecaster's own chance of this, stated with the estimate: 45%; middle value at least 1.5-fold (0.17 log units) away from the limit.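

In this assay compound 4 stands as a limit, as compound 3 does, so the step between them cannot be read. A saturated butyl chain alone does not bring back a measured number: methyl in place of isopropyl on the chain gives an at least 2.6-fold higher number from compound 1 to compound 4 (0.42 log units; beyond the scatter). Of the compounds shown, only compound 1, with its isopentyl chain, gives a number, and the others share one limit: the limit of > 30000 nM in this assay, at which 3 of the 4 values shown sit.

Going by these compounds, how far compound 3 and compound 4 lie beyond that limit stays open, and so does whether 3-methylbut-2-en-1-yl and butyl differ at all. Also open, on these data alone, is whether a longer chain than isopentyl, such as hexyl, or an amine at the end of the chain would give a lower number in this assay.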